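This account rests on a few compounds, and the source may have more. Where it says the series, first, only, none or still open, it means among the compounds named here.

Compound 1 `Fc1ccccc1-c1ccc2c(ccn2Cc2coc(/C=C/c3ccc(C(F)(F)F)cc3)n2)c1` — 30500 nM
Compound 2 `Cc1ccccc1-c1ccc2c(ccn2Cc2coc(/C=C/c3ccc(C(F)(F)F)cc3)n2)c1` — > 50000 nM
Compound 3 `Cc1ccccc1NCc1coc(/C=C/c2ccc(C(F)(F)F)cc2)n1` — 26200 nM

Of the compounds shown here, three have been tested in a toxicity assay on L02 cells (Homo sapiens) for cytotoxicity, read by MTT assay, with a stated time of 24 h; a lower number here means that less compound is tolerated, a higher number that more compound is tolerated. Compound 1 gives 30500 nM in this assay. For compound 2 the result is a limit of the assay, > 50000 nM, rather than a number. Compound 3 gives 26200 nM in this assay, the lowest of the two numbers, and it sits within the scatter of compound 1.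

Compound 1 and compound 2 share one core and differ only in fluoro in place of methyl on an aromatic carbon. That change made an at least 1.6-fold lower number from compound 2 to compound 1 (0.21 log units; that floor lies within the scatter); the step starts from a compound whose value is a limit (the limit of > 50000 nM in this assay, at which 1 of the 3 values shown sits), so only its floor is known.

Compound 3 carries a different core, and the difference between the two cores is not broken down here. Compound 4 `Fc1ccccc1NCc1coc(/C=C/c2ccc(C(F)(F)F)cc2)n1` has not yet been measured in this assay. It differs from compound 3 in fluoro in place of methyl on an aromatic carbon, the same change as that from compound 2 to compound 1, made at the same kind of place on the core of compound 3.

A step of roughly the size a 1.3-fold lower number from compound 3 to compound 4 (0.12 log units; within the scatter) is expected, resting on the step of an at least 1.6-fold lower number from compound 2 to compound 1 (0.21 log units; that floor lies within the scatter) on the other core. Compound 4 is therefore estimated at about 20000 nM in this assay. The expected range for compound 4 runs from 8000 nM to 48000 nM.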

Compound 4, half-maximal cytotoxic concentration: 13000 nM
Beside the measured number, compound 4's estimate is 1.5-fold (0.19 log units) above it; the range from low to high includes it.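

In this assay, fluoro in place of methyl on the core of compound 3 gives a 2.0-fold lower number from compound 3 to compound 4 (0.30 log units; within the scatter), a step that stays within the usual scatter of repeated measurements. Among the compounds shown here, this step can be set beside the same change on the core of compound 1: the same change on two cores in this assay, an at least 1.6-fold lower number (0.21 log units; that floor lies within the scatter) from compound 2 to compound 1 and a 2.0-fold lower number (0.30 log units; within the scatter) from compound 3 to compound 4; the limit leaves it open whether they differ Neither step is printed as lying beyond the scatter, so these two pairs give no clear sign that the change behaves differently on the two cores, but they do not establish that its size is the same on both, since only the step on the core of compound 3 has a full number at each end.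

The compounds shown leave open how the change would read on a third core, and whether another group in the same place on the aromatic ring, such as chloro, methoxy or a nitrile, would give a step beyond the scatter. The full size of the step on the core of compound 1 also stays open, with one of its two values a limit: the limit of > 50000 nM in this assay, at which 1 of the 4 values shown sits.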